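Swapping a methoxy for a pentyl on the aryl ring

The source may hold more compounds than are shown below. What is called first, only, known or untested is meant among the compounds shown, and "the series" means these compounds.

Three compounds share one core. Compound 1 `COc1ccc(N2C(=O)NC3(CSC4=C3C(=O)c3ncccc3C4=O)C2=O)cc1` gives 10 nM in a functional assay on CCRF-SB cells (Homo sapiens) for antiproliferative activity, read by MTT assay, with a stated time of 96 h (a higher number here means a weaker inhibitor, a lower number a stronger inhibitor), the lowest number of the three. Compound 2 `O=C1NNC(=O)C2(CSC3=C2C(=O)c2ncccc2C3=O)N1` gives 48 nM, and compound 3 `O=C1C2=C(C(=O)c3ncccc31)C1(CS2)NC(=O)N(c2ccccc2)C1=O` gives 30 nM. Within the data shown here, the one measured step that matters, a 3.0-fold higher number from compound 1 to compound 3 (0.48 log units; beyond the scatter), comes from removing the methoxy. Compound 4 `CCCCCc1ccc(N2C(=O)NC3(CSC4=C3C(=O)c3ncccc3C4=O)C2=O)cc1` differs from compound 1 by pentyl in place of methoxy on an aromatic carbon. That step and the earlier one share a position but not a direction, since a pentyl enters rather than nothing, so the earlier step only shows that this position is sensitive. He therefore expects a modest step, a 2.0-fold higher number from compound 1 to compound 4 (0.30 log units; within the scatter), leaning toward a higher number. Compound 4 is estimated at 20 nM, with a range from 5 nM to 80 nM.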

Compound 4, half-maximal inhibitory concentration: 150 nM
Compound 4: middle estimate off by 7.5-fold (0.88 log units), on the low side, and the stated range ends below it.
By their numbers in this assay, from the lowest: compound 1; then compounds 3 and 2 (each within the scatter of the next); then compound 4.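

In this assay pentyl costs far more at this aromatic carbon than the loss of methoxy did, with a 15-fold higher number from compound 1 to compound 4 (1.18 log units; beyond the scatter) on the swap, and a 5.0-fold higher number from compound 3 to compound 4 (0.70 log units; beyond the scatter) shows that pentyl also falls behind plain hydrogen there. The position therefore does not simply accept any added group: relative to hydrogen, methoxy lowers the number while pentyl raises it. No supporting data explain this difference. As far as these compounds go, whether the number climbs steadily with chain length remains open, as an ethyl or propyl chain would show. From the compounds shown here alone, how an amine or a carboxylic acid on this carbon would read also stays unknown.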